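A few compounds are considered here, and "the series" means these few. Any claim that something is new, unique, unknown or untested is made for them only; others in the source may bear on it.

Compound 1 `O=C(O)c1nn(Cc2cc(Br)ccc2OCc2ccccc2)cc1Br` gives 457 nM in an assay on CHO-K1 cells for displacement of a labelled ligand from prostaglandin E2 receptor EP1 subtype (Homo sapiens); a higher number here means a weaker inhibitor, a lower number a stronger inhibitor. Within the data shown here, compound 2 `Cc1cc(C(=O)O)nn1Cc1cc(Br)ccc1OCc1ccc(Cl)cc1` gives 8.71 nM in this assay, the lowest of the three numbers so far; compound 3 `Cc1cc(C(=O)O)nn1Cc1cc(Br)ccc1OCc1ccc(C(F)(F)F)cc1` gives 35.5 nM. Among the measured compounds shown here, the only single-point step available, a 4.1-fold higher number from compound 2 to compound 3 (0.61 log units; beyond the scatter), shows that exchanging the group on the outer aromatic ring moves the number by a modest amount and beyond the scatter. For the measured compounds named here, compound 1 stands much higher than compound 2, but no single-point step connects the two, so its value is only a reference point here.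

Compound 4 `Cc1cccc(COc2ccc(Br)cc2Cn2nc(C(=O)O)cc2C)c1` has not been measured. It differs from compound 2 by 3-methylphenyl in place of 4-chlorophenyl on a saturated chain carbon bound to an oxygen on an aromatic ring. Going by the values given here, no measured pair shows this exact exchange. The step from compound 2 to compound 3 is the one that bears on it, since it too alters the outer aromatic ring, and it was modest. Compound 4 is therefore expected to sit modestly higher, an estimated step of a 2.9-fold higher number from compound 2 to compound 4 (0.46 log units; beyond the scatter), though the gap could also fall within the scatter. The estimate for compound 4 in this assay is 25 nM, with a range from 8 nM to 80 nM.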

Compound 4, half-maximal inhibitory concentration: 126 nM
For compound 4 the middle estimate is 5.0-fold (0.70 log units) below the measured one, outside the stated range (above it).
By their numbers in this assay, from the lowest: compound 2; then compound 3; then compound 4; then compound 1.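

In this assay, the exchange of 4-chlorophenyl for 3-methylphenyl gives a 14-fold higher number from compound 2 to compound 4 (1.16 log units; beyond the scatter), a large step that shows the outer aromatic ring can move the number much further than a 4.1-fold higher number from compound 2 to compound 3 (0.61 log units; beyond the scatter) alone indicated. Both exchanges raise the number, and the groups in the new pair have the same heavy-atom count, so among the compounds sharing this core a matched count does not keep the number near that of compound 2. Nothing available explains the size of the new step.

The new exchange changes both the substituent and its place on the ring, so the compounds shown do not separate the loss of chloro, the arrival of methyl and the shift in placement. A methoxy group or a nitrile on the same outer ring, together with a matched pair that keeps the substituent and changes only its place, would show which of these carries the step.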